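The compounds below may be only part of what the source reports. "The series", "measured", "known", "first", "only" and "open" are said of these compounds alone.

Of the compounds shown here, three sharing one core have been measured in an assay for inhibition of Thromboxane-A synthase (Homo sapiens), using microsomes; on this read-out higher numbers stand for weaker inhibition and lower numbers for stronger inhibition: compound 1 `CSc1ccc(OC(C)(C)C2OCC(C/C=C\CCC(=O)O)C(c3cccnc3)O2)c([N+](=O)[O-])c1` gives 22 nM, compound 2 `CSc1ccccc1OC(C)(C)C1OCC(C/C=C\CCC(=O)O)C(c2cccnc2)O1` gives 36 nM, and compound 3 `CC(C)(Oc1ccccc1Br)C1OCC(C/C=C\CCC(=O)O)C(c2cccnc2)O1` gives 29 nM. On the numbers shown, compound 3 has the second highest of the three, with compound 2 nearest and compound 1 furthest, though all three values lie within the scatter of each other. Compound 4 `CC(C)(Oc1ccccc1[N+](=O)[O-])C1OCC(C/C=C\CCC(=O)O)C(c2cccnc2)O1` carries nitro in place of bromo on an aromatic carbon. The measured steps on this ring, a 1.2-fold lower number from compound 2 to compound 3 (0.09 log units; within the scatter), a 1.3-fold higher number from compound 1 to compound 3 (0.12 log units; within the scatter) and a 1.6-fold higher number from compound 1 to compound 2 (0.21 log units; within the scatter), all lie within the scatter, and none of them exchanges a bromo for a nitro. Compound 4 is therefore expected to show a 1.0-fold lower number from compound 3 to compound 4 (0.02 log units; within the scatter). For compound 4 the estimate is 28 nM, with a range from 14 nM to 56 nM.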

Compound 4, half-maximal inhibitory concentration: < 10 nM
Compound 4: only a limit was reported; the forecaster's own chance of this, stated with the estimate: 2%; middle value at least 2.8-fold (0.44 log units) away from the limit.
By their numbers in this assay, from the lowest: compounds 1, 3 and 2 (each within the scatter of the next). At a limit, below all of these: compound 4.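

In this assay compound 4 is reported only as a limit: the limit of < 10 nM in this assay, at which 1 of the 4 values shown sits. For the compounds shown here, on an aromatic carbon ortho to a large group, nitro gives the first steps beyond the scatter, with an at least 2.9-fold lower number from compound 3 to compound 4 (0.46 log units; beyond the scatter) for the exchange of bromo and an at least 3.6-fold lower number from compound 2 to compound 4 (0.55 log units; beyond the scatter) for the exchange of methylsulfanyl. Nitro alone does not decide this, since compound 1 also carries it, and hydrogen in place of its methylsulfanyl gives an at least 2.2-fold lower number from compound 1 to compound 4 (0.34 log units; beyond the scatter).

The limit leaves the full size of these steps open. As far as these compounds go, whether an amine or a nitrile at this position would match nitro also remains open.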